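The source may report more compounds than this note shows. Statements on the series, on what has been measured and on what is new or still open speak of the compounds shown alone.

In an assay on HEK293 cells for agonist activity at Toll-like receptor 8 (Homo sapiens), read by a luciferase reporter, with a stated time of 6 h (on this read-out lower numbers stand for an effect already at smaller amounts and higher numbers for an effect only at larger amounts of compound), compound 1 `CCCCNc1nc(N)nc2c1CN(C(=O)c1ccccc1)CC2` gives 1.4 uM, compound 2 `CCCCNc1nc(N)nc2c1CN(Cc1cccnc1)CC2` gives 0.13 uM and compound 3 `CCCCNc1nc(N)nc2c1CN(Cc1ccncc1)CC2` gives 0.29 uM. Among these three numbers compound 3 stands second highest: a 2.2-fold higher number from compound 2 to compound 3 (0.35 log units; beyond the scatter), while a 4.8-fold lower number from compound 1 to compound 3 (0.68 log units; beyond the scatter). Compound 4 `CCCCNc1nc(N)nc2c1CN(C(=O)CC)CC2` differs from compound 3 at the same place, on an amine nitrogen in a ring: propanoyl in place of (pyridin-4-yl)methyl on an amine nitrogen in a ring. The step that bears on this is the exchange of benzoyl for (pyridin-4-yl)methyl, a 4.8-fold lower number from compound 1 to compound 3 (0.68 log units; beyond the scatter), and the companion step an 11-fold lower number from compound 1 to compound 2 (1.03 log units; beyond the scatter) points the same way; moving back toward an acyl group therefore suggests a higher number, though propanoyl itself has not been measured. Compound 4 is expected to show a 3.4-fold higher number from compound 3 to compound 4 (0.54 log units; beyond the scatter). The estimate for compound 4 is 1 uM, within 0.3 uM to 3.5 uM.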

Compound 4, minimum effective concentration: 0.4 uM
For compound 4 the middle estimate is 2.5-fold (0.40 log units) above the measured one; low and high end bracket the measured number.
By their numbers in this assay, from the lowest: compound 2; then compounds 3 and 4 (each within the scatter of the next); then compound 1.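

On the amine nitrogen in the ring, a carbonyl-bound group does not by itself bring a high number in this assay: with ethyl in place of phenyl on the carbonyl carbon, the data show a 3.5-fold lower number from compound 1 to compound 4 (0.54 log units; beyond the scatter). Propanoyl and (pyridin-4-yl)methyl cannot be told apart (a 1.4-fold higher number from compound 3 to compound 4 (0.14 log units; within the scatter)), whereas (pyridin-3-yl)methyl keeps its lead over propanoyl (a 3.1-fold higher number from compound 2 to compound 4 (0.49 log units; beyond the scatter)). Nothing available explains these steps. Open, going by these compounds, is how a longer acyl chain such as hexanoyl would read at this nitrogen. Also open, on these data alone, is how a plain propyl group would compare with propanoyl there.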